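This account rests on a few compounds, and the source may have more. Where it says the series, first, only, none or still open, it means among the compounds named here.

Measured compounds:
compound 1, `O=C(Nc1ccc(Cl)c(-c2nnc3c(Cl)cccn23)c1)c1cccnc1`, > 100000 nM
compound 2, `O=C(Nc1ccc(Cl)c(-c2nnc3c(Cl)cccn23)c1)c1ccc(C(F)(F)F)cc1F`, > 100000 nM

In a functional assay on A549 cells (Homo sapiens) for antiproliferative activity, read by MTT assay, with a stated time of 72 h (on this read-out higher numbers stand for weaker inhibition and lower numbers for stronger inhibition), compound 1 gives > 100000 nM, which is a limit of the assay and not a number. Compound 2, which carries a different aryl amide on the shared core, also sits at a limit in this assay, > 100000 nM. For the measured compounds named here, compound 1 therefore stands on nothing firmer than a limit, and the only other value shown is a limit as well: the limit of > 100000 nM in this assay, at which 2 of the 2 values shown sit. Going by the values given here, no step between two measured compounds can be counted here, as neither value is a number.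

Compound 3, `O=C(Nc1ccc(Cl)c(-c2nnc3c(Cl)cccn23)c1)c1c(F)cccc1Cl`, differs from compound 1 in one place: 2-chloro-6-fluorophenyl in place of pyridin-3-yl on a carbonyl carbon. The measured values give no direction for this kind of exchange. Among the compounds with values here, compound 2 is the only guide, and in this assay it too sits at a limit, > 100000 nM. No movement beyond the scatter is expected from compound 1 to compound 3, and the most likely outcome is another limit. Compound 3 is estimated at 100000 nM, with a range from 30000 nM to 300000 nM. The expected step of a number no higher from compound 1 to compound 3 (the limit leaves the size open) is essentially none.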

Compound 3, half-maximal inhibitory concentration: 72300 nM
Compound 3: the middle estimate sits 1.4-fold (0.14 log units) above what was measured, and the stated range covers the measured number.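

In this assay compound 3 gives 72300 nM, so a group on this carbonyl carbon now has a measured number, which neither earlier compound provided. Putting 2-chloro-6-fluorophenyl in place of pyridin-3-yl gives an at least 1.3-fold lower number from compound 1 to compound 3 (0.14 log units; that floor lies within the scatter); compound 1 holds only a limit, so this step has a floor and its true size remains unread. The new number therefore shows that this position can yield a readable value in this assay, but it does not show that the exchange moves the result beyond the scatter, and most of the values still rest on the assay's limit: the limit of > 100000 nM in this assay, at which 2 of the 3 values shown sit.

The compounds shown leave open whether the chlorine, the fluorine or both in 2-chloro-6-fluorophenyl matter for reaching a readable value, and what an amine, a carboxylic acid or a longer alkyl chain would give on this carbonyl carbon. They also leave open whether a change elsewhere on the shared core, such as a methoxy group in place of a chlorine, would give a clearly lower number.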